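Compound 2 and an unmeasured ring exchange

The source may hold more compounds than are shown below. What is called first, only, known or untested is meant among the compounds shown, and "the series" means these compounds.

compound 1 `CC(C)CNC(=O)n1c(=O)oc2ccc(C3CCN(C)CC3)cc21`: 60000 nM
compound 2 `CC(C)N1CCC(c2ccc3c(c2)oc(=O)n3C(=O)NCCCCc2ccccc2)CC1`: 50000 nM
compound 3 `CN1CCC(c2ccc3c(c2)oc(=O)n3C(=O)NCCCCc2ccc(F)cc2)CC1`: 22000 nM

In a physicochemical assay for solubility, read by HPLC, in phosphate buffer, measured as kinetic solubility, with a stated time of 1 h, at pH 7.4, tested at 250 uM (on this read-out lower numbers stand for lower solubility and higher numbers for higher solubility), compound 2 stands at 50000 nM and sits within the scatter of compound 1 at 60000 nM on the same read-out. Compound 3 reads 22000 nM and lies lower than compound 2 by a gap beyond the scatter. Among the measured compounds shown here, no two of these three compounds differ in one place only, so no measured step isolates a single structural change.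

Compound 4 `CN1CCN(c2ccc3c(c2)oc(=O)n3C(=O)NCCCCc2ccccc2)C(=O)C1` has not yet been measured. It departs from compound 2 in one place, and the change is 4-methyl-2-oxopiperazin-1-yl in place of 1-isopropylpiperidin-4-yl on an aromatic carbon while the rest of the structure stays the same. For the measured compounds named here, with no measured step to draw on, the expectation rests on the spread of the three numbers, which has compound 3 at 22000 nM at one end and compound 1 at 60000 nM at the other on this read-out. A somewhat lower number is expected for compound 4 in this assay and the drop may well stay within the scatter. The expected change is a 1.7-fold lower number from compound 2 to compound 4 (0.22 log units; within the scatter) and this remains an estimate. Compound 4 is estimated at 30000 nM with an expected range from 10000 nM to 90000 nM in this read-out.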

Compound 4, solubility: 20000 nM
Compound 4: the middle estimate sits 1.5-fold (0.18 log units) above what was measured, and the stated range covers the measured number.
By their numbers in this assay, from the lowest: compounds 4 and 3 (each within the scatter of the next); then compounds 2 and 1 (each within the scatter of the next).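

In this assay, among the compounds shown here, 4-methyl-2-oxopiperazin-1-yl in place of 1-isopropylpiperidin-4-yl gives the first comparison in this set that isolates a single structural change: a 2.5-fold lower number from compound 2 to compound 4 (0.40 log units; beyond the scatter). It shows that this aromatic carbon, described as meta to a fused ring and para to a fused ring, is a place where exchanging one six-membered non-aromatic ring for another moves the read-out beyond the scatter, although the step is modest and neither group carries a net charge. Nothing measured here accounts for the size or direction of this step, which rests on this one pair alone.

The exchange alters several things at once, including the hetero atoms in the ring and the carbonyl, so the compounds shown leave open which of these changes goes with the step; a 4-methylpiperazin-1-yl or a morpholin-4-yl group on the same aromatic carbon would help separate them. They also leave open whether the step would keep its size with a shorter chain in place of the four-carbon phenyl-bearing chain that compound 2 and compound 4 share.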